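Moving the acetyl group: working notes toward compound 3

The compounds below may be only part of what the source reports. "The series", "measured", "known", "first", "only" and "open" are said of these compounds alone.

Measured so far:
compound 1 `CC(=O)c1ccc(Nc2ccnc(SCC(=O)c3ccc(Br)cc3)n2)cc1`: 14%
compound 2 `CC(=O)c1cccc(Nc2ccnc(SCC(=O)c3ccc(-c4ccccc4)cc3)n2)c1`: 13%

Both numbers come from a functional assay on SN12C cells (Homo sapiens) for inhibition, read by sulforhodamine B assay, with a stated time of 48 h, tested at 10 uM; on this read-out lower numbers stand for less inhibition of growth and higher numbers for more inhibition of growth at the one concentration tested. Compound 2 stands at the lower of the two values, with compound 1 a single point higher; that gap lies within the scatter, so the two read as the same. Compound 3 `CC(=O)c1ccc(Nc2ccnc(SCC(=O)c3ccc(-c4ccccc4)cc3)n2)cc1` has not yet been measured in this assay. It is built from compound 2 by one change: 4-acetylphenyl in place of 3-acetylphenyl on a nitrogen on an aromatic ring. Within the data shown here, no step between measured compounds is available to calibrate this change, and the two values in hand sit close together at low inhibition, which gives no basis for expecting movement in either direction. The working expectation is that the step from compound 2 to compound 3 stays within the scatter, estimated at a number 1 percentage points higher from compound 2 to compound 3 (within the scatter). Compound 3 is accordingly expected to give about 14% in this assay, with a range of 4% to 26%.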

Compound 3, percent growth inhibition at one concentration: 11%
Beside the measured number, compound 3's estimate is 3 percentage points above it; the range from low to high includes it.
By their numbers in this assay, from the lowest: compounds 3, 2 and 1 (each within the scatter of the next).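

In this assay, 4-acetylphenyl in place of 3-acetylphenyl on a nitrogen on an aromatic ring gives a number 2 percentage points lower from compound 2 to compound 3 (within the scatter), so these two acetylphenyl groups read alike at this position. The series now also has a step for phenyl in place of bromo on an aromatic carbon, which gives a number 3 percentage points lower from compound 1 to compound 3 (within the scatter), so that change likewise leaves the read-out inside the scatter with 4-acetylphenyl held constant. No measurement on hand bears on why either step stays this small.

From the compounds shown here alone, all three compounds sit together at low inhibition, so it remains open whether either position can move the number at all. A carboxylic acid or an amine in place of the acetyl group, or a pyridine in place of the terminal phenyl, would test this.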